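The source may hold more compounds than are shown below. What is called first, only, known or untested is meant among the compounds shown, and "the series" means these compounds.

Measured so far in an in vitro ADME assay on microsomes from liver (Homo sapiens) for pharmacokinetics, read by LC-MS; on this read-out higher numbers stand for fast clearance and lower numbers for slow clearance:

compound 1 `Cc1cccc2c1nc(C)n2-c1ccc(C(=O)NC2CC2)s1` gives 10 mL/min/kg
compound 2 `Cc1ccc2nc(C)n(-c3ccc(C(=O)NC4CC4)s3)c2c1` gives 10 mL/min/kg
compound 3 `Cc1nc2cc(C(F)(F)F)ccc2n1-c1ccc(C(=O)NC2CC2)s1` gives 4 mL/min/kg

Compound 1 stands level with compound 2, and together they hold the highest number of the three. Compound 3, which carries a trifluoromethyl group, gives the lowest number, and its gap to compound 1 lies beyond the scatter of repeated measurements.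

Compound 4 `Cc1nc2c(F)cccc2n1-c1ccc(C(=O)NC2CC2)s1` has not yet been measured. It keeps the core of compound 1 and changes one place, with fluoro in place of methyl on an aromatic carbon. For the measured compounds named here, no two measured compounds here differ in one place only, so the data offer no direct precedent for this swap. Going by the values given here, the one lead is that compound 3, at 4 mL/min/kg, is the only measured compound containing fluorine and reads below the other two. Among the compounds with values here, that is a single compound rather than a pattern, and its group differs from the one in compound 4. A modest move toward slower clearance in this assay is therefore expected, and it may not exceed the scatter. The expected change is a 1.5-fold lower number from compound 1 to compound 4 (0.19 log units; within the scatter), a step estimated to be small. For compound 4 the estimated clearance is 6.5 mL/min/kg, with an expected range from 3.5 mL/min/kg to 12 mL/min/kg.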

Compound 4, clearance: < 4 mL/min/kg
Compound 4: no number, only a limit; the forecaster's own chance of this, stated with the estimate: 3%; middle value at least 1.6-fold (0.21 log units) away from the limit.
By their numbers in this assay, from the lowest: compound 3; then compounds 1 and 2 (each within the scatter of the next).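

In this assay compound 4 gives < 4 mL/min/kg, and this value is a limit of the assay, not a number. The earlier compounds shown here offered no step that differed in one place, whereas fluoro in place of methyl on an aromatic carbon, ortho to a fused ring, now gives an at least 2.5-fold lower number from compound 1 to compound 4 (0.39 log units; beyond the scatter), so at this position the change carries the read-out past the scatter and does not stay inside it as first expected. That step has a floor but no upper end, so its true size remains unread, and only one compound in the set sits at this limit: the limit of < 4 mL/min/kg in this assay, at which 1 of the 4 values shown sits.

The compounds shown leave open how far under the limit compound 4 truly lies, and whether the same swap at the other aromatic carbons of the shared core would give a step of similar size. They also leave open how a chloro, methoxy or nitrile group in this same place would read in this assay, and so whether the step belongs to fluoro itself or simply to the loss of methyl.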